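From difluoromethoxy to diethylamino on a shared core

A few compounds are considered here, and "the series" means these few. Any claim that something is new, unique, unknown or untested is made for them only; others in the source may bear on it.

Results in a functional assay on HeLa cells (Homo sapiens) for antiproliferative activity, read by resazurin assay; a higher number here means a weaker inhibitor, a lower number a stronger inhibitor:
- compound 1 `CCSC(=S)SCC(=O)c1ccc(NS(C)(=O)=O)cc1`: 39800 nM
- compound 2 `[C-]#[N+]c1ccc(C(=O)CSC(=S)SCC)cc1`: 7940 nM
- compound 3 `CCSC(=S)SCC(=O)c1ccc(OC(F)F)cc1`: 3980 nM

Compound 3 shares the low end of these numbers with compound 2, as the measured change is a 2.0-fold lower number from compound 2 to compound 3 (0.30 log units; within the scatter). Compound 1 lies clearly apart, with a 10-fold lower number from compound 1 to compound 3 (1.00 log units; beyond the scatter) and a 5.0-fold lower number from compound 1 to compound 2 (0.70 log units; beyond the scatter).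

The next compound, compound 4 `CCSC(=S)SCC(=O)c1ccc(N(CC)CC)cc1`, carries diethylamino in place of difluoromethoxy on an aromatic carbon. All three measured steps exchange the group at this same place, but none of them tests diethylamino. The large steps all start from compound 1, while the swap that links compound 2 and compound 3 stays within the scatter. The expectation therefore leans on that smaller step, with a wide margin towards the value of compound 1 at 39800 nM. The expected step is a 1.5-fold higher number from compound 3 to compound 4 (0.18 log units; within the scatter), which is not expected to exceed the scatter. The estimate for compound 4 is 6000 nM, with an expected range of 2000 nM to 20000 nM.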

Compound 4, half-maximal inhibitory concentration: 3160 nM
Compound 4: middle estimate off by 1.9-fold (0.28 log units), on the high side; low and high end bracket the measured number.
By their numbers in this assay, from the lowest: compounds 4, 3 and 2 (each within the scatter of the next, the first and the last beyond it); then compound 1.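

In this assay, the exchange of difluoromethoxy for diethylamino on the aromatic carbon gives a 1.3-fold lower number from compound 3 to compound 4 (0.10 log units; within the scatter), so this position accepts the two groups alike, despite their different atoms. Diethylamino also provides the first step beyond the scatter among the three compounds at the low end, a 2.5-fold lower number from compound 2 to compound 4 (0.40 log units; beyond the scatter), and the only step graded large so far, a 13-fold lower number from compound 1 to compound 4 (1.10 log units; beyond the scatter). Nothing available explains these differences.

The compounds shown leave open whether a smaller amine such as dimethylamino, a ring amine such as morpholine, or a carboxylic acid at this place would keep the number at this level. Among these compounds, they also vary only this one group, so the effect of changes elsewhere on the shared core remains untested.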